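Methoxy for amino on the phenoxy ring of compound 3

The source may hold more compounds than are shown below. What is called first, only, known or untested is meant among the compounds shown, and "the series" means these compounds.

Of the compounds shown here, three have been measured in a functional assay on L1210 cells (Mus musculus) for antiproliferative activity, read by cell counting, with a stated time of 96 h; a lower number here means a stronger inhibitor, a higher number a weaker inhibitor. Compound 3 `CC(Nc1ccccc1Oc1cccc(N)c1)=C1C(=O)CC(c2ccccc2)CC1=O` gives 53 nM, the lowest number of the three and the most potent on these data, since both of its steps to the others lie beyond the scatter. Compound 1 `COc1ccc(Oc2ccccc2NC(C)=C2C(=O)CC(c3ccccc3)CC2=O)cc1` gives 140 nM and compound 2 `CC(Nc1ccccc1Oc1cccc(F)c1)=C1C(=O)CC(c2ccccc2)CC1=O` gives 330 nM; the shift from compound 2 to compound 3 is a 6.2-fold lower number from compound 2 to compound 3 (0.79 log units; beyond the scatter), and from compound 1 to compound 3 it is a 2.6-fold lower number from compound 1 to compound 3 (0.42 log units; beyond the scatter).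

Compound 4 `COc1cccc(Oc2ccccc2NC(C)=C2C(=O)CC(c3ccccc3)CC2=O)c1` has not been measured. It differs from compound 3 by methoxy in place of amino on an aromatic carbon. The bearing steps are the gain on going from compound 2 to compound 3 when amino replaced fluoro, and the gain from compound 1 to compound 3 when 3-aminophenyl replaced 4-methoxyphenyl; both point to amino as the favourable group, while methoxy in compound 1 stood between fluoro and amino. Going by the values given here, no measured step places methoxy meta to a large group, so the expectation is only that removing amino costs potency. The step from compound 3 to compound 4 in this assay is therefore expected to be an increase in the number, roughly a 2.8-fold higher number from compound 3 to compound 4 (0.45 log units; beyond the scatter). Compound 4 is estimated at 150 nM, with a range of 60 nM to 400 nM.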

Compound 4, half-maximal inhibitory concentration: 58 nM
Estimate against measurement, compound 4: 2.6-fold (0.41 log units) above; measured number below the stated range.
By their numbers in this assay, from the lowest: compounds 3 and 4 (each within the scatter of the next); then compound 1; then compound 2.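

In this assay the amino group on this aromatic carbon proves replaceable, since methoxy gives a 1.1-fold higher number from compound 3 to compound 4 (0.04 log units; within the scatter) and so matches amino here despite the loss of the hydrogen-bond donor counted for amino. The gain over fluoro survives that replacement, with a 5.7-fold lower number from compound 2 to compound 4 (0.76 log units; beyond the scatter) as the step for methoxy in place of fluoro, so of the three groups at this place only fluoro gives a number beyond the scatter from the others. Going by these compounds alone, the methoxy pair adds the first reading on where the group stands on the phenoxy ring: a 2.4-fold lower number from compound 1 to compound 4 (0.38 log units; beyond the scatter) is the step for 3-methoxyphenyl in place of 4-methoxyphenyl.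

Still open, from the compounds shown here alone, is whether ethoxy, hydroxyl or dimethylamino on the same carbon would stay level with compound 3 and compound 4, and whether 4-aminophenyl would show the same dependence on placement as the methoxy pair. Nothing available here bears on the reason for these steps.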